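Swapping nitro for methoxy on an analogue with a high number in this assay

The compounds below may be only part of what the source reports. "The series", "measured", "known", "first", "only" and "open" are said of these compounds alone.

Measured compounds:
- compound 1, `CCCc1n[nH]c2c(=O)n(NC(=O)c3ccccc3)c(-c3cccc([N+](=O)[O-])c3)nc12`, 27.8%
- compound 2, `CCCc1n[nH]c2c(=O)n(NC(=O)c3ccccc3)c(-c3cccc(OC)c3)nc12`, 23.6%
- compound 3, `O=C(Nn1c(-c2cccc([N+](=O)[O-])c2)nc2c(-c3cccc(Cl)c3)n[nH]c2c1=O)c1ccccc1`, 93.8%

All three share a common core and were tested in a functional assay on DU-145 cells (Homo sapiens) for cytotoxicity, read by sulforhodamine B assay, with a stated time of 2 days, tested at 100 uM; a higher number here means more inhibition at the concentration tested (going by the name of the read-out), a lower number less inhibition. Compound 3 stands highest of the three numbers: it lies a number 66 percentage points higher from compound 1 to compound 3 (beyond the scatter), and its gap to compound 2 is larger still, so its standing above both is beyond the scatter.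

Compound 4, `COc1cccc(-c2nc3c(-c4cccc(Cl)c4)n[nH]c3c(=O)n2NC(=O)c2ccccc2)c1`, has not yet been measured. It differs from compound 3 in one place: methoxy in place of nitro on an aromatic carbon.

Within the data shown here, the one measured step that bears on this change is the same swap made on compound 1, which gave a number 4.2 percentage points lower from compound 1 to compound 2 (within the scatter), so that step was within the scatter. On that basis the same swap on compound 3 is expected to leave the result in this assay essentially unchanged, with no step beyond the scatter in either direction; the step is estimated as a number 5.8 percentage points lower from compound 3 to compound 4 (within the scatter). Compound 4 is therefore estimated at 88%, with a range from 70% to 99%.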

Compound 4, a percentage reported as inhibition, at one concentration (the size of the read-out at that concentration, not a potency): 93.5%
For compound 4 the middle estimate is 5.5 percentage points below the measured one; the range from low to high includes it.
By their numbers in this assay, from the lowest: compounds 2 and 1 (each within the scatter of the next); then compounds 4 and 3 (each within the scatter of the next).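

Methoxy in place of nitro now gives a number 0.3 percentage points lower from compound 3 to compound 4 (within the scatter), so in this assay the change from 3-nitrophenyl to 3-methoxyphenyl leaves the number in place on a compound with a high number as well as on one with a low number: the same change on two cores in this assay, a number 4.2 percentage points lower (within the scatter) from compound 1 to compound 2 and a number 0.3 percentage points lower (within the scatter) from compound 3 to compound 4, 3.9 percentage points apart, within the scatter of two such steps. The swap of propyl for 3-chlorophenyl also carries over to the methoxy compounds, with a number 69.9 percentage points higher from compound 2 to compound 4 (beyond the scatter), so the large rise is not confined to the nitro pair: the same change on two cores in this assay, a number 66 percentage points higher (beyond the scatter) from compound 1 to compound 3 and a number 69.9 percentage points higher (beyond the scatter) from compound 2 to compound 4, 3.9 percentage points apart, within the scatter of two such steps. Across these four compounds, the number follows the group that replaces propyl and not the group on the other phenyl ring.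

As far as these compounds go, whether an amine or a carboxylic acid on that phenyl ring would also leave the number in place remains open. So does whether a longer chain or an unsubstituted phenyl in place of propyl would bring a similar rise.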